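Rearranging the Ester Side Chain on a Quinone Core

The compounds below may be only part of what the source reports. "The series", "measured", "known", "first", "only" and "open" are said of these compounds alone.

Of the compounds shown here, two sharing one core have been measured in a functional assay on HeLa cells (Homo sapiens) for cytotoxicity, read by MTT assay; a lower number here means a stronger inhibitor, a higher number a weaker inhibitor. Among the measured compounds shown here, compound 2 `CC[C@@](C)(O)CC(=O)O[C@H](CC=C(C)C)C1=CC(=O)c2c(O)ccc(O)c2C1=O` gives 17900 nM, and compound 1 `CC(=O)OCCC(=O)O[C@H](CC=C(C)C)C1=CC(=O)c2c(O)ccc(O)c2C1=O` gives 17300 nM; the step of a 1.0-fold higher number from compound 1 to compound 2 (0.01 log units; within the scatter) lies within the scatter, so compound 2 stands level with its only neighbour. Compound 3 `CCC(CO[C@H](CC=C(C)C)C1=CC(=O)c2c(O)ccc(O)c2C1=O)OC(C)=O` has the same atoms as compound 2 joined differently: 2-acetoxybutyl in place of (2-hydroxy-2-methylbutyl)carbonyl on an oxygen on a saturated carbon. For the measured compounds named here, the only measured step bearing on this change is the flat one from compound 1 to compound 2, so the expected step of a 1.0-fold higher number from compound 2 to compound 3 (0.00 log units; within the scatter) is none beyond the scatter. Compound 3 is therefore estimated at 18000 nM, with a range from 9000 nM to 36000 nM.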

Compound 3, half-maximal inhibitory concentration: 44000 nM
Compound 3: the middle estimate sits 2.4-fold (0.39 log units) below what was measured, and the stated range ends below it.
By their numbers in this assay, from the lowest: compounds 1 and 2 (each within the scatter of the next); then compound 3.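

Compounds 1 and 2 suggested that this position tolerates rearrangement, but that holds only while the side chain stays joined through its carbonyl. In this assay, 2-acetoxybutyl, which has a saturated carbon on that oxygen, gives a 2.5-fold higher number from compound 2 to compound 3 (0.39 log units; beyond the scatter) and a 2.5-fold higher number from compound 1 to compound 3 (0.41 log units; beyond the scatter), and the hydroxy group alone does not separate compound 3, as compound 1 also lacks it. Nothing available explains this rise.

As far as these compounds go, the link and the rest of the chain change together in compound 3, so their separate contributions remain open. How an amine or a carboxylic acid on this chain would fare is also unknown.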